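Chloro for methoxy on the best of three

The source may report more compounds than this note shows. Statements on the series, on what has been measured and on what is new or still open speak of the compounds shown alone.

Of the compounds shown here, three share one core and have been measured in a functional assay on A549 cells (Homo sapiens) for antiproliferative activity, read by MTT assay, with a stated time of 72 h; on this read-out lower numbers stand for stronger inhibition and higher numbers for weaker inhibition. Among the measured compounds shown here, compound 1 `COc1cccc(N2C(=O)COc3ccc(-c4cnc(Cl)c(NS(=O)(=O)c5ccc(F)cc5)c4)cc32)c1` gives 32700 nM, and compound 2 `O=C1COc2ccc(-c3cnc(Cl)c(NS(=O)(=O)c4ccc(F)cc4)c3)cc2N1C1CCCCC1` gives 37900 nM; the only step measured, a 1.2-fold higher number from compound 1 to compound 2 (0.06 log units; within the scatter), is small. Compound 3 `COc1ncc(-c2ccc3c(c2)N(C2CC2)C(=O)CO3)cc1NS(=O)(=O)c1ccc(F)cc1` gives 3320 nM, the lowest of the three numbers, with compound 1 nearest and compound 2 furthest, both beyond the scatter.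

Compound 4 `O=C1COc2ccc(-c3cnc(Cl)c(NS(=O)(=O)c4ccc(F)cc4)c3)cc2N1C1CC1` is the next compound to be measured. It differs from compound 3 in a single place: chloro in place of methoxy on an aromatic carbon. For the measured compounds named here, no measured step bears directly on this exchange, since the one measured step concerns a different part of the molecule and lies within the scatter. Compounds 1 and 2 also carry chloro, and both sit far above compound 3, but they differ from compound 4 elsewhere as well, so their numbers do not settle what the chloro alone does.

Without a direct precedent, compound 4 is expected to land between the chloro-bearing pair and compound 3, with the step from compound 3 estimated as a 3.6-fold higher number from compound 3 to compound 4 (0.56 log units; beyond the scatter). Compound 4 is therefore expected to give about 12000 nM, within a wide range from 3000 nM to 45000 nM.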

Compound 4, half-maximal inhibitory concentration: 4330 nM
Estimate against measurement, compound 4: 2.8-fold (0.44 log units) above; measured number inside the range.
By their numbers in this assay, from the lowest: compounds 3 and 4 (each within the scatter of the next); then compounds 1 and 2 (each within the scatter of the next).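

On the aromatic carbon next to the ring nitrogen and ortho to the ((4-fluorophenyl)sulfonyl)amino group, the exchange of methoxy for chloro in this assay gives a 1.3-fold higher number from compound 3 to compound 4 (0.12 log units; within the scatter) and so leaves the number unchanged when cyclopropyl sits on the amide-type nitrogen. With chloro held in place, the group on that nitrogen does matter: cyclopropyl in place of cyclohexyl gives an 8.8-fold lower number from compound 2 to compound 4 (0.94 log units; beyond the scatter) and cyclopropyl in place of 3-methoxyphenyl gives a 7.6-fold lower number from compound 1 to compound 4 (0.88 log units; beyond the scatter) in the same read-out, so among these single-place steps the nitrogen substituent alone moves the number beyond the scatter. Nothing measured on these compounds explains either the flat exchange on the aromatic carbon or the steps on the nitrogen.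

Going by these compounds, it remains open whether methoxy and chloro would also match with cyclohexyl or 3-methoxyphenyl on the nitrogen, since only the cyclopropyl pair compares them directly. Also open, on these data alone, is how an amine or a nitrile on the same aromatic carbon would read, and where a methyl or a cyclobutyl on the nitrogen would fall.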